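The source may report more compounds than this note shows. Statements on the series, on what has been measured and on what is new or still open speak of the compounds shown alone.

In an ADME assay for permeability, using PAMPA, at pH 7.4 (a higher number here means that the compound crosses the layer faster, a lower number that the compound crosses the layer more slowly), compound 1 (`C[C@@H]1CN(c2cccc3c2C[C@H](CN(C)[C@H]2CCCc4cccnc42)NC3)C[C@H](C)N1`) gives 39 nm/s, within the scatter of compound 2 (`CCN(C[C@H]1Cc2c(cccc2N2CCNCC2)CN1)[C@H]1CCCc2cccnc21`) at 75 nm/s and higher than compound 3 (`CC(C)N(C[C@H]1Cc2c(cccc2N2CCNCC2)CN1)[C@H]1CCCc2cccnc21`) at 16 nm/s, the lowest of the three. Compound 4 (`C[C@@H]1CN(c2cccc3c2C[C@H](CN(C)[C@H]2CCCc4cccnc42)NC3)C[C@H](C)N1C`) carries methyl in place of hydrogen on an amine nitrogen in a ring. For the measured compounds named here, the one measured methyl step, a 4.7-fold lower number from compound 2 to compound 3 (0.67 log units; beyond the scatter), sits on a saturated chain carbon bound to an amine nitrogen and a saturated chain carbon, so it is only a loose guide. Going by the values given here, no measured step places methyl on a ring nitrogen. The expected change is small, a 1.3-fold higher number from compound 1 to compound 4 (0.11 log units; within the scatter), probably not beyond the scatter. For compound 4 the estimated value is 50 nm/s, with an expected range from 18 nm/s to 130 nm/s.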

Compound 4, apparent permeability: 142 nm/s
The estimate for compound 4 lay 2.8-fold (0.45 log units) below the measured number, and the stated range ends below it.
By their numbers in this assay, from the lowest: compound 3; then compounds 1, 2 and 4 (each within the scatter of the next, the first and the last beyond it).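

On the amine nitrogen in a ring of the 3,5-dimethylpiperazin-1-yl group, next to two ring atoms that each bear a methyl group, methyl in place of hydrogen gives (a 3.6-fold higher number from compound 1 to compound 4 (0.56 log units; beyond the scatter)) in (this assay). A single added methyl therefore need not lower the number, as the step on a saturated chain carbon did (a 4.7-fold lower number from compound 2 to compound 3 (0.67 log units; beyond the scatter)). Nothing given here accounts for the opposite direction of the two steps.

On these data alone, whether an ethyl group or an acetyl group on the same ring nitrogen would move the number the same way remains open. So does whether methyl would do so without the two ring methyl groups.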